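Pyridin-3-yl Replaces 4-Methylphenyl: a Low Response Expected

A few compounds are considered here, and "the series" means these few. Any claim that something is new, unique, unknown or untested is made for them only; others in the source may bear on it.

Compound 1 `CC(Oc1ccccc1-c1ccc([N+](=O)[O-])cc1)C1=NCCN1`: in a functional assay on CHO cells for agonist activity at Alpha-2B adrenergic receptor (Homo sapiens) (on this read-out lower numbers stand for smaller maximal responses and higher numbers for larger maximal responses), compound 1 gives < 0.3, a limit of the assay rather than a number.
Compound 2 `Cc1ccc(-c2ccccc2OC(C)C2=NCCN2)cc1`: in this assay compound 2 gives < 0.3, again a limit of the assay.

Compound 2 therefore stands only at a limit, with no exact number known. Going by the values given here, the single measured step, a step that the two limits leave unreadable from compound 1 to compound 2, cannot be read in size because both of its ends sit at the limit of < 0.3 in this assay, at which 2 of the 2 values shown sit. Compound 3 `CC(Oc1ccccc1-c1cccnc1)C1=NCCN1` differs from compound 2 by pyridin-3-yl in place of 4-methylphenyl on an aromatic carbon. Among the compounds with values here, no measured step bears on this change, so no shift beyond the usual scatter is expected in either direction. Compound 3 is expected to give 0.2, most likely between 0.05 and 0.45. The step this estimate implies is a step that the limit leaves unreadable from compound 2 to compound 3, expected to stay within the scatter.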

Compound 3, intrinsic activity: the largest response reached, as a fraction of the reference agonist's: 0.5
Compound 3: middle estimate off by 0.30, on the low side; the measured number lies above the stated range.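

Replacing 4-methylphenyl with pyridin-3-yl on this aromatic carbon gives, in this assay, a number at least 0.20 higher from compound 2 to compound 3 (beyond the scatter). The maximal response at this position therefore depends on the ring attached there, and a ring with one nitrogen can give a clearly larger response than the 4-methylphenyl ring. Compound 3 gives a readable number, whereas compound 1 and compound 2 stay at a limit: the limit of < 0.3 in this assay, at which 2 of the 3 values shown sit.

The compounds shown cannot separate the effect of the ring nitrogen from the loss of the methyl group. As far as these compounds go, whether plain phenyl or pyridin-4-yl at the same place would give a similar response remains open.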